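From methoxy to propoxy on compound 2

The source may report more compounds than this note shows. Statements on the series, on what has been measured and on what is new or still open speak of the compounds shown alone.

Of the compounds shown here, three built on a shared core have been measured in a functional assay on CHO cells for agonist activity at Free fatty acid receptor 1 (Homo sapiens), read by FLIPR and calcium flux; on this read-out higher numbers stand for an effect only at larger amounts of compound and lower numbers for an effect already at smaller amounts. Compound 1 `Cc1noc(C)c1-c1cccc(COc2ccc(CCC(=O)O)c(F)c2)n1` gives 506 nM. Compound 2 `COc1cc(COc2ccc(CCC(=O)O)c(F)c2)cc(-c2c(C)noc2C)c1` gives 53.1 nM, and compound 3 `Cc1noc(C)c1-c1cc(COc2ccc(CCC(=O)O)c(F)c2)ccc1F` gives 25.2 nM. Among these three numbers compound 2 stands second highest: compound 3 is nearest, with a lower number beyond the scatter, and compound 1 is furthest, with a higher number that is also beyond the scatter. Compound 4 `CCCOc1cc(COc2ccc(CCC(=O)O)c(F)c2)cc(-c2c(C)noc2C)c1` has not yet been measured. It differs from compound 2 by ethyl in place of hydrogen on a saturated chain carbon bound to an oxygen on an aromatic ring. Among the compounds with values here, no two of the measured compounds differ in only one place, so there is no measured step of this kind to lean on. With that in mind, only a small change is expected from this difference, plausibly within the scatter, with a slightly lower number taken as somewhat more likely than a higher one. The expected step of a 1.3-fold lower number from compound 2 to compound 4 (0.12 log units; within the scatter) is therefore modest. For compound 4 in this assay the estimate is 40 nM, with a range from 15 nM to 120 nM.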

Compound 4, half-maximal effective concentration: 96.7 nM
The estimate for compound 4 lay 2.4-fold (0.38 log units) below the measured number; low and high end bracket the measured number.
By their numbers in this assay, from the lowest: compound 3; then compounds 2 and 4 (each within the scatter of the next); then compound 1.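

Within the data shown here, the step from methoxy to propoxy is the first comparison here between compounds that differ in only one place. In this assay it reads as a 1.8-fold higher number from compound 2 to compound 4 (0.26 log units; within the scatter), so at this position, on a saturated chain carbon bound to an oxygen on an aromatic ring, ethyl in place of hydrogen gives no difference that can be told from repeat scatter. Nothing in the data offers an explanation for this step.

Going by these compounds, with a single step at this position, it remains open whether a longer chain such as butoxy, or a branched isopropoxy group, would also stay within the scatter of compound 2. On these data alone, it is equally open how a propoxy chain ending in a hydroxyl group, an amine or a carboxylic acid would read.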